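Swapping cyclopropyl for 2-chlorophenyl on a carbonyl carbon

This account rests on a few compounds, and the source may have more. Where it says the series, first, only, none or still open, it means among the compounds named here.

In a physicochemical assay for solubility (on this read-out lower numbers stand for lower solubility and higher numbers for higher solubility), compound 1 (`CCCS(=O)(=O)N1CCC(CNC(=O)C2CC2)(C(=O)N2CCOCC2)CC1`) gives 10000 ug/mL and stands level with compound 2 (`CCCS(=O)(=O)N1CCC(CNC(=O)c2c(F)cccc2F)(C(=O)N2CCOCC2)CC1`) at 10000 ug/mL on this measure. Compound 3 (`CCCS(=O)(=O)N1CCC(CNC(=O)c2ccccc2Cl)(C(=O)N2CCOCC2)CC1`) carries 2-chlorophenyl in place of cyclopropyl on a carbonyl carbon. Within the data shown here, only one measured step bears on this, the swap to 2,6-difluorophenyl on that carbonyl carbon (no change at the digits printed from compound 1 to compound 2 (within the scatter)). With that single guide, no step beyond the scatter is expected in this assay for this change. The expected step is a 1.1-fold lower number from compound 1 to compound 3 (0.05 log units; within the scatter) on this estimate. Compound 3 is expected at 9000 ug/mL with a likely range of 3000 ug/mL to 11000 ug/mL overall.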

Compound 3, solubility: 10000 ug/mL
Beside the measured number, compound 3's estimate is 1.1-fold (0.05 log units) below it; the measured number falls inside the stated range.
By their numbers in this assay, from the lowest: compounds 1, 2 and 3 (each within the scatter of the next).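

In this assay the swap to 2-chlorophenyl on this carbonyl carbon leaves the number unmoved (no change at the digits printed from compound 1 to compound 3 (within the scatter)), and so does the exchange of the two aromatic groups (no change at the digits printed from compound 2 to compound 3 (within the scatter)). So two different halogen-bearing phenyl groups, each larger than cyclopropyl, now sit at this position with the same read-out as cyclopropyl. No measured evidence offers a reason for this. From the compounds shown here alone, whether a phenyl carrying an amine or a carboxylic acid would shift the number stays open. So does the effect of a longer chain in this place.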